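Compound 3 to compound 4: replacing naphthalen-2-yl

This account rests on a few compounds, and the source may have more. Where it says the series, first, only, none or still open, it means among the compounds named here.

Compound 3 `CN(C(=O)c1csc(-c2cccnc2)n1)c1ccc(OCc2ccc3ccccc3c2)cc1` stands in an ADME assay (liver) for metabolic stability, with Liver microsome (Rattus norvegicus) as the target, using microsomes (on this read-out lower numbers stand for slow clearance and higher numbers for fast clearance), at > 283 mL/min/kg, which is a limit of the assay and not a number. Compound 4 `CN(C(=O)c1csc(-c2cccnc2)n1)c1ccc(OCB2C=Cc3ccccc3N2)cc1` keeps everything else in compound 3 and changes in one place: a group of 10 heavy atoms (8 carbon, 1 boron, 1 nitrogen; one six-membered non-aromatic ring with 2 hetero atoms, one six-membered aromatic ring of carbon only) in place of a group of 10 heavy atoms (10 carbon; 2 six-membered aromatic rings of carbon only), on a saturated chain carbon bound to an oxygen on an aromatic ring.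

Among the compounds with values here, no measured step makes this exchange directly. Compound 1 `CN(C(=O)c1cc(-c2ccccn2)[nH]n1)c1ccc(OCB2C=Cc3ccccc3N2)cc1` carries the entering group and gives 25 mL/min/kg, and compound 2 `CN(C(=O)c1ccc2ncsc2c1)c1ccc(OCB2C=Cc3ccccc3N2)cc1` carries it too and gives 73.3 mL/min/kg. Both also differ from compound 3 in the group on the carbonyl carbon, so the comparison is indirect. Within the data shown here, the one measured step, a 2.9-fold higher number from compound 1 to compound 2 (0.47 log units; beyond the scatter), lies at that carbonyl end and shows that the group there also moves the number, by a modest amount.

A large step towards a lower number is therefore expected in this assay, resting on compound 1 at 25 mL/min/kg and compound 2 at 73.3 mL/min/kg. The expected change is an at least 4.7-fold lower number from compound 3 to compound 4 (0.67 log units; beyond the scatter). Compound 4 is estimated at 60 mL/min/kg, with an expected range of 20 mL/min/kg to 180 mL/min/kg.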

Compound 4, clearance: > 283 mL/min/kg
Compound 4 ended at the assay's limit; the forecaster's own chance of this, stated with the estimate: 5%; middle value at least 4.7-fold (0.67 log units) away from the limit.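

In this assay compound 4 gives > 283 mL/min/kg, which is a limit of the assay and not a number. With the group on the saturated chain carbon held the same, 2-(pyridin-3-yl)-1,3-thiazol-4-yl on the carbonyl carbon gives an at least 3.8-fold higher number from compound 2 to compound 4 (0.58 log units; beyond the scatter) and an at least 11-fold higher number from compound 1 to compound 4 (1.05 log units; beyond the scatter), so the carbonyl end spans a wider range in this read-out than the earlier step there showed. The exchange of naphthalen-2-yl for the boron-containing group cannot be sized from compound 3 to compound 4, because both compounds stand at the same limit: the limit of > 283 mL/min/kg in this assay, at which 2 of the 4 values shown sit.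

As far as these compounds go, whether that exchange lowers the number at all remains open. A compound with naphthalen-2-yl and 5-(pyridin-2-yl)-1H-pyrazol-3-yl on the carbonyl carbon could bring it into readable range, and an amine on the saturated chain carbon would test a different kind of group there.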